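Difluoroethyl in place of difluoromethyl: what to expect

The source may hold more compounds than are shown below. What is called first, only, known or untested is meant among the compounds shown, and "the series" means these compounds.

Measured so far in an ADME assay on cells for inhibition of cytochrome P450 11B1, mitochondrial (Homo sapiens), read by HPLC, with a stated time of 60 min; on this read-out lower numbers stand for stronger inhibition and higher numbers for weaker inhibition:
compound 1 `Fc1cc2nc(-c3cncnc3)n(C3CC3)c2cc1F` gives 2270 nM
compound 2 `CC(C)c1ncncc1-c1nc2cc(F)c(F)cc2n1C1CC1` gives 1910 nM
compound 3 `Fc1cc2nc(-c3cncnc3C(F)F)n(C3CC3)c2cc1F` gives 4330 nM

Compound 3 has the highest of the three numbers in this assay. Its gap to compound 1 is small, as a 1.9-fold higher number from compound 1 to compound 3 (0.28 log units; within the scatter) shows, while the gap to compound 2 is modest but real, as a 2.3-fold higher number from compound 2 to compound 3 (0.36 log units; beyond the scatter) shows. Compound 1 and compound 2 themselves sit within the scatter of each other, as a 1.2-fold lower number from compound 1 to compound 2 (0.07 log units; within the scatter) shows.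

Compound 4 `CC(F)(F)c1ncncc1-c1nc2cc(F)c(F)cc2n1C1CC1` is not yet measured. It differs from compound 3 by methyl in place of hydrogen on a saturated chain carbon bound to an aromatic carbon and two fluorine atoms. Within the data shown here, three measured steps bear on this change, all at the same aromatic carbon: adding isopropyl to hydrogen changed little, adding difluoromethyl to hydrogen changed little, and swapping isopropyl for difluoromethyl raised the number modestly. The new group is between difluoromethyl and isopropyl in its makeup, so a small drop in the number, or no change beyond the scatter, is expected.

Compound 4 is therefore estimated at 3000 nM in this assay, with a range from 1400 nM to 6500 nM, which corresponds to an expected step of a 1.4-fold lower number from compound 3 to compound 4 (0.16 log units; within the scatter).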

Compound 4, half-maximal inhibitory concentration: 5720 nM
The estimate for compound 4 lay 1.9-fold (0.28 log units) below the measured number; the measured number falls inside the stated range.
By their numbers in this assay, from the lowest: compounds 2, 1, 3 and 4 (each within the scatter of the next, the first and the last beyond it).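

In this assay, the step of a 1.3-fold higher number from compound 3 to compound 4 (0.12 log units; within the scatter) shows that adding methyl to the saturated chain carbon bound to the aromatic carbon and two fluorine atoms has no effect that can be told from the scatter. Among these compounds, the larger comparison with the unsubstituted compound is new: the step of a 2.5-fold higher number from compound 1 to compound 4 (0.40 log units; beyond the scatter) lies beyond the scatter, so 1,1-difluoroethyl is the first group here to separate clearly from hydrogen at this aromatic carbon, whereas neither isopropyl in compound 2 nor difluoromethyl in compound 3 does so. The step of a 3.0-fold higher number from compound 2 to compound 4 (0.48 log units; beyond the scatter) is also beyond the scatter, and since the step from compound 2 to compound 3 is too, both groups bearing fluorine give higher numbers than isopropyl, though all of these differences remain modest.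

Still open, as far as these compounds go, is how this aromatic carbon would respond to other groups, such as trifluoromethyl, cyclopropyl, methoxy or an amine, and whether any of them would give a clearly lower number than hydrogen does. The compounds shown come with no measurement that explains any of these steps.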